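Second trifluoromethyl on compound 3

This account rests on a few compounds, and the source may have more. Where it says the series, first, only, none or still open, it means among the compounds named here.

Values measured in a functional assay on MDA-MB-231 cells (Homo sapiens) for antiproliferative activity, read by sulforhodamine B assay, with a stated time of 72 h (a higher number here means a weaker inhibitor, a lower number a stronger inhibitor), are as follows:
- compound 1 `COc1ccc2nc(Cl)c(/C=C\c3ccc(C(F)(F)F)cc3)cc2c1` gives 22800 nM
- compound 2 `FC(F)(F)c1cccc(/C=C\c2cc3ccccc3nc2Cl)c1` gives 3750 nM
- compound 3 `COc1ccc2nc(Cl)c(/C=C\c3cccc(C(F)(F)F)c3)cc2c1` gives 3280 nM

Compound 3 sits level with compound 2 within the scatter, while compound 1 stands apart from both with a higher number, beyond the scatter. The next compound is compound 4 `COc1ccc2nc(Cl)c(/C=C\c3cc(C(F)(F)F)cc(C(F)(F)F)c3)cc2c1` and it has not been measured. It differs from compound 3 by trifluoromethyl in place of hydrogen on an aromatic carbon and the new group stands on a six-membered aromatic ring of carbon only, meta to a trifluoromethyl group.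

Going by the values given here, the only measured step is a 1.1-fold lower number from compound 2 to compound 3 (0.06 log units; within the scatter) and it lies within the scatter. That step concerns methoxy, so it bears on the present change only indirectly. Among the compounds with values here, no measured step adds a trifluoromethyl group, and the data give no direction for one. The gap between compound 1 at 22800 nM and compound 3 at 3280 nM shows that values in this small set can lie well apart, so the range is kept wide. In this assay no step beyond the scatter is expected, and the estimated step is a 1.1-fold higher number from compound 3 to compound 4 (0.03 log units; within the scatter) with no firm direction. For compound 4 the estimated value is 3500 nM with an expected range from 1200 nM to 11000 nM in these notes.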

Compound 4, half-maximal inhibitory concentration: 4470 nM
The estimate for compound 4 lay 1.3-fold (0.11 log units) below the measured number; low and high end bracket the measured number.
By their numbers in this assay, from the lowest: compounds 3, 2 and 4 (each within the scatter of the next); then compound 1.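

In this assay the added trifluoromethyl, on the six-membered aromatic ring of carbon only and meta to a trifluoromethyl group, gives a 1.4-fold higher number from compound 3 to compound 4 (0.13 log units; within the scatter) and so leaves the number level with that of compound 3 within the scatter. Going by these compounds alone, this is the first measured step that adds a trifluoromethyl group, and it shows that this position takes a second one without a shift that can be told from the scatter, though it gives no gain in strength either. No measurement here bears on why this step stays so small.

Still open, going by these compounds, is how this position responds to groups of a different kind, for instance an amine or a carboxylic acid in place of the added trifluoromethyl, since a single substitution here says nothing about whether any group at this position could move the number beyond the scatter. Also open, on these data alone, is whether the same trifluoromethyl added to compound 2, which has hydrogen in place of the methoxy on the shared core, would give a step of similar size.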